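Cytotoxicity Limits in Three Analogues and a Methyl Variant

This account rests on a few compounds, and the source may have more. Where it says the series, first, only, none or still open, it means among the compounds named here.

Three compounds share one core and differ only in the ring attached to the carbonyl carbon: compound 1 `COC(=O)c1cc(-c2cccc(NC(=O)c3ccc(/C=C/C(=O)c4cccc([N+](=O)[O-])c4)cc3)c2)on1`, compound 2 `COC(=O)c1cc(-c2cccc(NC(=O)c3ccc(/C=C/C(=O)c4ccc(OC)cc4)cc3)c2)on1` and compound 3 `COC(=O)c1cc(-c2cccc(NC(=O)c3ccc(/C=C/C(=O)c4cccc(OC)c4)cc3)c2)on1`. In an ADME assay on Vero cells (Chlorocebus sabaeus) for cytotoxicity, read by MTT assay, with a stated time of 72 h (a lower number here means that less compound is tolerated, a higher number that more compound is tolerated), compound 1 gives no number but a limit, > 40 ug/mL. Compound 2 likewise gives a limit, > 10 ug/mL, so its standing among the three is known only as a limit (the limit of > 10 ug/mL in this assay, at which 1 of the 3 values shown sits). Compound 3 also gives a limit, > 100 ug/mL. Consequently the steps a step that the two limits leave unreadable from compound 1 to compound 2, a step that the two limits leave unreadable from compound 1 to compound 3 and a step that the two limits leave unreadable from compound 2 to compound 3 cannot be read in size or direction. Compound 4 `COC(=O)c1cc(-c2cccc(NC(=O)c3ccc(/C=C/C(=O)c4ccc(C)cc4)cc3)c2)on1` differs from compound 2 by methyl in place of methoxy on an aromatic carbon. With no readable step to draw on, the step that the limit leaves unreadable from compound 2 to compound 4 is expected to be small. Compound 4 is therefore estimated at 40 ug/mL, between 10 ug/mL and 100 ug/mL.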

Compound 4, half-maximal cytotoxic concentration: > 80 ug/mL
Compound 4 gave a limit, no number (the forecaster's own chance of this, stated with the estimate: 80%); middle value at least 2.0-fold (0.30 log units) from the limit.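

For the compounds shown here, compound 4, like compound 1, compound 2 and compound 3, gives only a limit, and no step among them can be read. On these data alone, whether methyl in place of methoxy changes the tolerated concentration at all stays open.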